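Methyl to Ethoxy: A Step Expected Within the Scatter

The compounds below may be only part of what the source reports. "The series", "measured", "known", "first", "only" and "open" are said of these compounds alone.

- Compound 1 `Nc1ccc(/C=C/C(=O)c2ccccc2)cc1`: 36000 nM
- Compound 2 `Nc1ccc(/C=C/C(=O)c2ccc(Br)cc2)cc1`: 49000 nM
- Compound 3 `Cc1ccc(C(=O)/C=C/c2ccc(N)cc2)cc1`: 40000 nM

In a functional assay on HeLa cells (Homo sapiens) for antiproliferative activity, with a stated time of 48 h (a higher number here means a weaker inhibitor, a lower number a stronger inhibitor), the three measured compounds lie close together. Compound 3 shows no separation from either neighbour, with a 1.1-fold higher number from compound 1 to compound 3 (0.05 log units; within the scatter) and a 1.2-fold lower number from compound 2 to compound 3 (0.09 log units; within the scatter).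

The next compound is compound 4 `CCOc1ccc(C(=O)/C=C/c2ccc(N)cc2)cc1`, which carries ethoxy in place of methyl on an aromatic carbon, para to a large group: ethoxy in place of methyl on an aromatic carbon. Among the measured compounds shown here, no measured compound carries ethoxy, so the evidence is indirect. The nearest guides are the other changes at an aromatic carbon, namely a 1.4-fold higher number from compound 1 to compound 2 (0.13 log units; within the scatter) and a 1.1-fold higher number from compound 1 to compound 3 (0.05 log units; within the scatter). Neither moved the number beyond the scatter, and replacing bromo with methyl did not either, giving a 1.2-fold lower number from compound 2 to compound 3 (0.09 log units; within the scatter). No step beyond the scatter is therefore expected in this assay, and no direction can be favoured.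

The expected change is a 1.1-fold lower number from compound 3 to compound 4 (0.02 log units; within the scatter). For compound 4 the estimated value is 38000 nM, with an expected range of 19000 nM to 75000 nM.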

Compound 4, half-maximal inhibitory concentration: 41000 nM
The estimate for compound 4 lay 1.1-fold (0.03 log units) below the measured number; the measured number falls inside the stated range.
By their numbers in this assay, from the lowest: compounds 1, 3, 4 and 2 (each within the scatter of the next).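

In this assay, the change at this carbon para to a large group brought in ethoxy, with 3 heavy atoms and 1 hydrogen-bond acceptor, for methyl, with 1 heavy atom and no acceptor, yet the numbers did not separate (a 1.0-fold higher number from compound 3 to compound 4 (0.01 log units; within the scatter)). Among the compounds shown here, the same holds when ethoxy is set against the other two groups at this carbon (a 1.2-fold lower number from compound 2 to compound 4 (0.08 log units; within the scatter); a 1.1-fold higher number from compound 1 to compound 4 (0.06 log units; within the scatter)), so hydrogen, bromo, methyl and ethoxy now all lie within the scatter of one another, and the one group with an oxygen atom is no exception. Nothing in the available data offers an explanation for this lack of separation.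

From the compounds shown here alone, it remains open whether a carboxylic acid or an amine at this carbon, or an alkoxy chain longer than ethoxy, would move the number beyond the scatter. The compounds shown also do not tell whether ethoxy would behave the same way at another carbon of this ring.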